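From a Furan to a Pyridine on a Shared Core

The source may hold more compounds than are shown below. What is called first, only, known or untested is meant among the compounds shown, and "the series" means these compounds.

Compound 1 `O=C(Nc1cccc(-c2ccoc2)c1)C(Cl)Cl` carries a furan-3-yl group on the shared core. In a functional assay on KB 3-1 cells (Homo sapiens) for cytotoxicity, read by MTT assay, with a stated time of 68 h (a lower number here means a stronger inhibitor, a higher number a weaker inhibitor), compound 1 gives > 50000 nM, which is a limit of the assay and not a number. Compound 2 `O=C(Nc1cccc(-c2ccc(-c3ccccc3)cc2)c1)C(Cl)Cl` belongs to the same series. In this assay compound 2 gives > 50000 nM, again a limit rather than a measured number. Both values therefore sit at the limit of > 50000 nM in this assay, at which 2 of the 2 values shown sit, so compound 1 stands neither above nor below compound 2; the two compounds cannot be told apart on these numbers, and neither shows measurable cytotoxicity.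

Compound 3 `O=C(Nc1cccc(-c2ccccn2)c1)C(Cl)Cl` has not yet been measured. It differs from compound 1 by pyridin-2-yl in place of furan-3-yl on an aromatic carbon. Within the data shown here, no step between measured compounds exists, so the only guide is that the two measured compounds both reach the limit. On that basis the step of a number no higher from compound 1 to compound 3 (the limit leaves the size open) is expected to be none beyond the scatter. Compound 3 is therefore expected to give about 50000 nM in this assay, within a range from 15000 nM to 150000 nM, and most likely to be reported again only as a limit.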

Compound 3, half-maximal inhibitory concentration: > 50000 nM
Compound 3 ended at the assay's limit; the forecaster's own chance of this, stated with the estimate: 75%; the middle value lies on the limit itself.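

Among these compounds, neither compound 1 nor compound 3 gives a number in this assay, so no step between them can be read from these two limits: the limit of > 50000 nM in this assay, at which 3 of the 3 values shown sit.

The compounds shown leave open whether pyridin-2-yl and furan-3-yl differ at all in this cytotoxicity, and whether any group on the shared core gives a measurable value.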